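Replacing a biphenyl with a phenoxyphenyl amide

The compounds below may be only part of what the source reports. "The series", "measured", "known", "first", "only" and "open" are said of these compounds alone.

Measured compounds:
- compound 1, `O=C(CCCCCCCCn1cc(-c2cccnc2)nn1)Nc1ccccc1-c1ccccc1`: 35.6%
- compound 2, `O=C(CCCCCCCn1cc(-c2cccnc2)nn1)Nc1ccccc1Cc1ccccc1`: 75.2%

In a functional assay on SH-SY5Y cells (Homo sapiens) for cytotoxicity, tested at 300 nM (a lower number here means a stronger effect, a higher number a weaker effect of the compound at the concentration tested), compound 1 gives 35.6%, the lowest of the two numbers, and compound 2 gives 75.2%, a gap beyond the scatter. Compound 3, `O=C(CCCCCCCCn1cc(-c2cccnc2)nn1)Nc1ccccc1Oc1ccccc1`, differs from compound 1 by phenoxy in place of phenyl on an aromatic carbon. Within the data shown here, no measured pair shows this change. The expectation is that the step of a number 19.4 percentage points higher from compound 1 to compound 3 (beyond the scatter) in this assay moves toward a weaker effect, of moderate size, though it could also fall within the scatter. Compound 3 is therefore estimated at 55%, within 30% to 80%.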

Compound 3, a percentage reported as activity, at one concentration (the size of the read-out at that concentration, not a potency): 79.5%
The estimate for compound 3 lay 24.5 percentage points below the measured number, within the range that was stated.
By their numbers in this assay, from the lowest: compound 1; then compounds 2 and 3 (each within the scatter of the next).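

In this assay the group on this aromatic carbon clearly matters: phenoxy in place of phenyl gives a large step toward a weaker effect, a number 43.9 percentage points higher from compound 1 to compound 3 (beyond the scatter), so adding one oxygen atom to the substituent is enough to change the read-out. Compound 1 and compound 3 differ only at this place, so the step can be assigned to this change alone. Nothing measured here explains why the oxygen has this effect. Still open, as far as these compounds go, is how an amine in place of the oxygen or a lone methoxy group would read out at this carbon. From the compounds shown here alone, it is also open whether the same swap gives a similar step on a longer or shorter chain.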